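The compounds below may be only part of what the source reports. "The series", "measured", "known", "first", "only" and "open" are said of these compounds alone.

Working notes on the series. Compound 1 `C=C1CCC[C@H]2[C@](C)(CCC(C)=O)[C@@H](C)CC[C@]12C` is the open-chain member; in a functional assay on MDA-N cells (Homo sapiens) for inhibition (on this read-out higher numbers stand for weaker inhibition of growth and lower numbers for stronger inhibition of growth), compound 1 gives > 15000 nM, which is a limit of the assay and not a number. One of the three values shown sits at the limit of > 15000 nM in this assay, at which 1 of the 3 values shown sits. The two cyclic peroxides carry numbers. Compound 2 `C=C1CCCC(C)(C)C1CC[C@]1(C)CC[C@H]([C@@H](C)C(=O)OC)OO1` gives 3540 nM in this assay. Compound 3 `C=C1CCCC(C)(C)C1CC[C@@]1(C)CC[C@H]([C@@H](C)C(=O)O)OO1` gives 3520 nM in this assay. Of the two numbers shown, compound 3 holds the lower one, but the gap to compound 2 is within the scatter, so no order between compound 2 and compound 3 is read from these data.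

Compound 4 `C=C1CCCC(C)(C)C1CC[C@]1(C)CC[C@@H]([C@@H](C)C(=O)O)OO1` is the next member to be measured. Relative to compound 3 the change is the two compounds have the same atoms and bonds; at least one stereo element is drawn with a configuration in one of them and without one in the other: 2 of 4 stereo elements differ; a stereocentre at a saturated ring carbon is drawn S in compound 3 and R in compound 4; a stereocentre at a saturated ring carbon is drawn R in compound 3 and S in compound 4. For the measured compounds named here, no step between measured compounds that differ in one place exists in this set, so the size of the change in this assay cannot be anchored on a measured pair. The expected step of a 1.4-fold higher number from compound 3 to compound 4 (0.15 log units; within the scatter) is modest, toward weaker inhibition, and not clearly beyond the scatter. Compound 4 is estimated at 5000 nM, with a range from 1500 nM to 15000 nM, and a real chance that the assay again returns only a limit.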

Compound 4, concentration for 50% growth inhibition: > 10000 nM
Compound 4 gave a limit, no number (the forecaster's own chance of this, stated with the estimate: 15%); middle value at least 2.0-fold (0.30 log units) away from the limit.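

With the same atoms and bonds on both sides, exchanging the drawn configuration at two stereocentres on saturated ring carbons gives an at least 2.8-fold higher number from compound 3 to compound 4 (0.45 log units; beyond the scatter) in this assay, a step toward weaker inhibition of growth. For the compounds shown here, this is the first readable evidence that configuration at these two ring carbons alone can shift this read-out, since no measured pair among the earlier compounds differed in one place. The step gives only a lower bound on the size of the change, and its true size cannot be read from a limit: the limit of > 10000 nM in this assay, at which 1 of the 4 values shown sits.

No compound shown changes one of the two stereocentres alone, and the share of each in the step cannot be read. As far as these compounds go, it also stays open whether the same exchange of configuration would give a comparable step with the methyl ester seen in compound 2, or with a primary amide in place of the carboxylic acid.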